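Same atoms, joined differently: the step to compound 3

The source may hold more compounds than are shown below. What is called first, only, known or untested is meant among the compounds shown, and "the series" means these compounds.

Compound 1 `CC(C)(C)Sc1c(CC(C)(C)C(=O)O)n(Cc2ccc(Cl)cc2)c2ccc(OCc3cc4ccccc4cn3)cc12`: > 3000 nM
Compound 2 `CC(C)(C)Sc1c(CC(C)(C)C(=O)O)n(Cc2ccc(Cl)cc2)c2ccc(OCc3ccc4cccnc4n3)cc12`: > 3000 nM

Both entries come from a functional assay (blood) for inhibition, with Homo sapiens as the target; on this read-out higher numbers stand for weaker inhibition and lower numbers for stronger inhibition. Compound 2 stands at > 3000 nM, which is a limit of the assay and not a number. Compound 1 gives > 3000 nM, which is also a limit. The whole picture so far is the limit of > 3000 nM in this assay, at which 2 of the 2 values shown sit. Among the compounds with values here, the one measured step is a step that the two limits leave unreadable from compound 1 to compound 2, so it offers no size to carry forward.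

Compound 3 `CC(C)(C)Sc1c(CC(C)(C)C(=O)O)n(Cc2ccc(Cl)cc2)c2ccc(OCc3ccc4cnccc4n3)cc12` keeps the core of compound 2 and differs only on a saturated chain carbon bound to an oxygen on an aromatic ring: a group of 10 heavy atoms (8 carbon, 2 nitrogen; 2 six-membered aromatic rings with 1 hetero atom each) in place of a group of 10 heavy atoms (8 carbon, 2 nitrogen; 2 six-membered aromatic rings with 1 hetero atom each), on a saturated chain carbon bound to an oxygen on an aromatic ring. Compound 2 offers no number to start from at > 3000 nM, so no step beyond the usual scatter is expected in this assay. The estimated change is a step that the limit leaves unreadable from compound 2 to compound 3. For compound 3 the expected value is 4000 nM, with an estimated range from 1500 nM to 10000 nM.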

Compound 3, half-maximal inhibitory concentration: 980 nM
Estimate against measurement, compound 3: 4.1-fold (0.61 log units) above; measured number outside the range, below it.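

The step shows that at this place, on a saturated chain carbon bound to an oxygen on an aromatic ring, rejoining the same atoms is enough to change the read-out in this assay, giving an at least 3.0-fold lower number from compound 2 to compound 3 (0.48 log units; beyond the scatter). The group with only one nitrogen gives the same picture, with an at least 3.0-fold lower number from compound 1 to compound 3 (0.48 log units; beyond the scatter). Both steps give only a smallest size, and the true gaps may be larger, because the other two compounds rest at a limit: the limit of > 3000 nM in this assay, at which 2 of the 3 values shown sit.

As far as these compounds go, how far the number can fall through changes at this place stays open. So does the effect of an amine or a methoxy group added to the group carried by compound 3.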